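This account rests on a few compounds, and the source may have more. Where it says the series, first, only, none or still open, it means among the compounds named here.

Measured so far in an assay on CHO cells for displacement of a labelled ligand from 5-hydroxytryptamine receptor 1B (Homo sapiens); a higher number here means a weaker inhibitor, a lower number a stronger inhibitor:

- compound 1 `O[C@H]1Cc2ccccc2C1NC1CCN(CCCc2c[nH]c3ccc(-n4cnnc4)cc23)CC1`: 300 nM
- compound 2 `CC(C)=CCCN(C)C1CCN(CCCc2c[nH]c3ccc(-n4cnnc4)cc23)CC1`: 24 nM
- compound 3 `c1cncc(CNC2CCN(CCCc3c[nH]c4ccc(-n5cnnc5)cc34)CC2)c1`: 140 nM

Compound 3 stands second highest of the three numbers. Its nearest neighbour is compound 1, with a 2.1-fold lower number from compound 1 to compound 3 (0.33 log units; beyond the scatter) between them; the furthest is compound 2, with a 5.8-fold higher number from compound 2 to compound 3 (0.77 log units; beyond the scatter). Compound 4 `C[C@H](NCC1CCN(CCCc2c[nH]c3ccc(-n4cnnc4)cc23)CC1)c1ccccc1` has not been measured. It differs from compound 3 as follows: ((1-phenylethyl)amino)methyl in place of ((pyridin-3-yl)methyl)amino on a saturated ring carbon.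

Going by the values given here, no measured step matches this change directly. The two steps that touch compound 3 both vary the group on the same saturated ring carbon: a 2.1-fold lower number from compound 1 to compound 3 (0.33 log units; beyond the scatter) was modest, and a 5.8-fold higher number from compound 2 to compound 3 (0.77 log units; beyond the scatter) was modest as well, with the largest step in the set, a 13-fold lower number from compound 1 to compound 2 (1.10 log units; beyond the scatter), separating the two aromatic-bearing amines from the open-chain tertiary amine of compound 2. Swaps of the substituent at this position have therefore moved this assay by modest to large amounts, in either direction. Given that compound 2 with its non-aromatic chain gives 24 nM while the aromatic-bearing compounds 1 and 3 sit higher, a modest lowering for compound 4 is expected, a 1.8-fold lower number from compound 3 to compound 4 (0.24 log units; within the scatter). Compound 4 is estimated at 80 nM, within 25 nM to 250 nM.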

Compound 4, half-maximal inhibitory concentration: 58 nM
Compound 4: middle estimate off by 1.4-fold (0.14 log units), on the high side; the measured number falls inside the stated range.
By their numbers in this assay, from the lowest: compound 2; then compound 4; then compound 3; then compound 1.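

In this assay, going by these compounds alone, compound 4 is the first whose amine reaches the saturated ring carbon through a methyl link and whose aromatic ring is carbon only, and it gives a 2.4-fold lower number from compound 3 to compound 4 (0.38 log units; beyond the scatter) and a 5.2-fold lower number from compound 1 to compound 4 (0.71 log units; beyond the scatter). Even so, the open-chain tertiary amine keeps the lowest number, with a 2.4-fold higher number from compound 2 to compound 4 (0.38 log units; beyond the scatter), so among these four compounds an aromatic ring in the substituent does not rule out a number within that modest step of compound 2. No measurement bears on why these numbers differ.

The step from compound 3 to compound 4 changes the ring, the methyl branch with its defined stereocentre and the link all at once, and the compounds shown do not separate these. A benzylamino group, a (pyridin-3-yl)methylaminomethyl group or the opposite stereocentre of the 1-phenylethyl group on the same ring carbon would each isolate one of those changes.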